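The source may hold more compounds than are shown below. What is called first, only, known or untested is meant among the compounds shown, and "the series" means these compounds.

Working notes on the series. In a functional assay on MCF7 cells (Homo sapiens) for antiproliferative activity, read by MTT assay, with a stated time of 48 h (on this read-out higher numbers stand for weaker inhibition and lower numbers for stronger inhibition), compound 1 `CCOc1cc(-c2ccc3c(ccn3C)c2)cn2c(-c3cc(OC)c(OC)c(OC)c3)nnc12` gives 140 nM and compound 2 `COc1cc(-c2nnc3c(OC4CCC4)cc(-c4ccc5c(ccn5C)c4)cn23)cc(OC)c1OC` gives 125 nM. These two values lie within the scatter of each other, so compound 2 stands level with compound 1, the only other measured point.

The next structure is compound 3 `CCCN1CC(Oc2cc(-c3ccc4c(ccn4C)c3)cn3c(-c4cc(OC)c(OC)c(OC)c4)nnc23)C1`, with the change (1-propylazetidin-3-yl in place of cyclobutyl on an oxygen on an aromatic ring). In words, 1-propylazetidin-3-yl stands in place of cyclobutyl on an oxygen on an aromatic ring. Among the measured compounds shown here, the one measured step at this place is a 1.1-fold lower number from compound 1 to compound 2 (0.05 log units; within the scatter), with cyclobutyl in place of ethyl. That step is small, but it covers only groups of carbon. For the measured compounds named here, no measured compound has a hetero atom in the group on this oxygen, so the new group is untested and the range must stay wide.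

In this assay, no step beyond the scatter is expected, with a slight lean towards a higher number as a judgement only. The expected step is a 1.4-fold higher number from compound 2 to compound 3 (0.16 log units; within the scatter). For compound 3 the estimated value is 180 nM, within an expected range of 60 nM to 550 nM.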

Compound 3, half-maximal inhibitory concentration: 378 nM
For compound 3 the middle estimate is 2.1-fold (0.32 log units) below the measured one; low and high end bracket the measured number.
By their numbers in this assay, from the lowest: compounds 2 and 1 (each within the scatter of the next); then compound 3.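

In this assay, the group on this oxygen now moves the number beyond the scatter, with a 3.0-fold higher number from compound 2 to compound 3 (0.48 log units; beyond the scatter) and a 2.7-fold higher number from compound 1 to compound 3 (0.43 log units; beyond the scatter), both modest in size. Ethyl and cyclobutyl had stood level, so the position is not indifferent to every group placed there, and 1-propylazetidin-3-yl, the only group here that contains a nitrogen, is the one that gives the higher number. No measurement on these compounds bears on the reason for this step.

This single change brings in the nitrogen, the propyl chain and a larger group all at once, so the compounds shown cannot say which of these goes with the higher number. Open questions are whether a methyl in place of the propyl on the azetidine, a carbon-only group such as cyclohexyl, or an oxygen-containing group such as oxetan-3-yl would stay level with compound 2 or follow compound 3.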